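The source may hold more compounds than are shown below. What is called first, only, known or untested is meant among the compounds shown, and "the series" means these compounds.

Compound 1 `CCc1cc2c(C(=O)c3ccc(OC)cc3)cc(OC)cc2o1` stands lowest of the three compounds measured in an assay for inhibition of solute carrier family 22 member 12 (Homo sapiens), read by scintillation counting, with a stated time of 60 min, tested at 50 uM; a higher number here means more inhibition at the concentration tested (going by the name of the read-out), a lower number less inhibition; in that assay compound 1 gives 1.5%. Compound 2 `CCc1cc2cc(O)cc(C(=O)c3ccc(OC)cc3)c2o1`, which carries a hydroxy on the shared core, gives 9.3% in this assay, a number within the scatter of compound 1. Among the measured compounds shown here, compound 3 `CCc1cc2c(C(=O)c3ccc(O)cc3)cc(OC)cc2o1` gives 62.4% in this assay, and the step of a number 60.9 percentage points higher from compound 1 to compound 3 (beyond the scatter) is the only single-change step measured here; it is hydrogen in place of methyl on an oxygen on an aromatic ring, on the benzoyl side of the molecule.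

Compound 4 `CCc1cc2c(C(=O)c3ccc(OC)cc3)cc(O)cc2o1` differs from compound 1 by hydrogen in place of methyl on an oxygen on an aromatic ring. The same kind of change at the other methoxy produced the large step from compound 1 to compound 3, which argues for an increase. Against that, compound 2 already carries a hydroxy on the shared core and shows 9.3%, within the scatter of compound 1. The account therefore expects only a modest rise, with the step of a number 13.5 percentage points higher from compound 1 to compound 4 (beyond the scatter) expected to be small. In this assay compound 4 is expected to give 15%, with a range from 2% to 45%.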

Compound 4, a percentage reported as inhibition, at one concentration (the size of the read-out at that concentration, not a potency): 12.4%
The estimate for compound 4 lay 2.6 percentage points above the measured number, within the range that was stated.
By their numbers in this assay, from the lowest: compounds 1, 2 and 4 (each within the scatter of the next, the first and the last beyond it); then compound 3.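

In this assay, replacing methoxy with hydroxy on the shared core gives a number 10.9 percentage points higher from compound 1 to compound 4 (beyond the scatter) and shows that this position responds to the change, though only modestly. The same change at the other methoxy of compound 1 gives a number 60.9 percentage points higher from compound 1 to compound 3 (beyond the scatter) and is much the larger of the two steps, so the two methoxy groups of compound 1 do not answer alike to one and the same replacement. Nothing available here accounts for that difference between the two places.

What the compounds shown leave open is whether hydroxy at both places would add to, match or undo what each replacement does alone, and whether a carboxylic acid or an amine in place of either methoxy would carry the number further than hydroxy does. Also open, as far as these compounds go, is whether a longer chain in place of the ethyl group would shift these numbers, and how the compounds would rank in potency, since each number here is the size of the read-out at a single concentration.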